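The source may report more compounds than this note shows. Statements on the series, on what has been measured and on what is new or still open speak of the compounds shown alone.

Compound 1, `O=C(CN1CCN(c2ccc(F)cc2)CC1)Nc1nc2c(s1)CCCC2`, compound 2, `O=C(CN1CCN(c2cccnc2)CC1)Nc1nc2c(s1)CCCC2`, and compound 3, `O=C(CN1CCN(c2ccccn2)CC1)Nc1nc2c(s1)CCCC2`, share one core and differ only in the aromatic group carried on an amine nitrogen in a ring. In an assay on isolated protein for inhibition of long-chain fatty acid transport protein 1 (Homo sapiens), read by scintillation counting, with a stated time of 20 min (on this read-out lower numbers stand for stronger inhibition and higher numbers for weaker inhibition), compound 1 gives 77 nM. Compound 2 reaches only the limit of this assay, > 1000 nM, and so its number is a limit rather than a value (the limit of > 1000 nM in this assay, at which 1 of the 3 values shown sits). Compound 3 gives 200 nM. Of the two numbers shown, compound 3 holds the higher one; its nearest neighbour is compound 1, through the step of a 2.6-fold higher number from compound 1 to compound 3 (0.41 log units; beyond the scatter). The remaining steps, an at least 12-fold higher number from compound 1 to compound 2 (1.11 log units; beyond the scatter) and an at least 5.0-fold lower number from compound 2 to compound 3 (0.69 log units; beyond the scatter), show that pyridin-3-yl weakens inhibition far more than pyridin-2-yl does.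

Compound 4, `O=C(CN1CCN(c2nccs2)CC1)Nc1nc2c(s1)CCCC2`, differs from compound 3 in one place: 1,3-thiazol-2-yl in place of pyridin-2-yl on an amine nitrogen in a ring. Both heteroaryl steps already seen, modest for pyridin-2-yl and large for pyridin-3-yl, bear on this exchange, but neither concerns 1,3-thiazol-2-yl itself. In this assay the step from compound 3 to compound 4 is expected to be small, a 1.3-fold higher number from compound 3 to compound 4 (0.10 log units; within the scatter), since the ring nitrogen keeps its position relative to the attachment. Compound 4 is therefore expected at about 250 nM, with a range from 90 nM to 700 nM.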

Compound 4, half-maximal inhibitory concentration: 520 nM
Beside the measured number, compound 4's estimate is 2.1-fold (0.32 log units) below it; measured number inside the range.
By their numbers in this assay, from the lowest: compound 1; then compound 3; then compound 4. At a limit, above all of these: compound 2.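

The step of a 2.6-fold higher number from compound 3 to compound 4 (0.41 log units; beyond the scatter) shows that, on this amine nitrogen in a ring, 1,3-thiazol-2-yl cannot stand in for pyridin-2-yl without a loss, so a five-membered aromatic ring with 2 hetero atoms is tolerated here but ranks behind the six-membered one. The step of a 6.8-fold higher number from compound 1 to compound 4 (0.83 log units; beyond the scatter) places it further from 4-fluorophenyl than pyridin-2-yl stands. Compound 2 holds a limit, and the step of an at least 1.9-fold lower number from compound 2 to compound 4 (0.28 log units; that floor lies within the scatter) does not settle how far 1,3-thiazol-2-yl stands from pyridin-3-yl because that number is not a value: the limit of > 1000 nM in this assay, at which 1 of the 4 values shown sits.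

The compounds shown leave open how plain phenyl without its fluorine would compare with 4-fluorophenyl on this nitrogen. They also leave open how a 1,3-oxazol-2-yl or pyrimidin-2-yl group would fall within this order.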